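From Butylamino to Phenyl: Expecting a Weaker Inhibitor

The source may hold more compounds than are shown below. What is called first, only, known or untested is meant among the compounds shown, and "the series" means these compounds.

Of the compounds shown here, three built on one shared core have been tested in an ADME assay on LL24 cells (Homo sapiens) for inhibition, read by MTT assay, with a stated time of 24 h; a lower number here means a stronger inhibitor, a higher number a weaker inhibitor. For the measured compounds named here, compound 2 `CCCCNc1ccc(C(=O)N/N=C/c2ccc([N+](=O)[O-])o2)cc1` gives 47000 nM, the only plain number among the three. Compound 1 `O=C(N/N=C/c1ccc([N+](=O)[O-])o1)c1ccccc1Oc1ccccc1` returns only a limit of the assay, > 200000 nM. Compound 3 `CCCCc1ccc(C(=O)N/N=C/c2ccc([N+](=O)[O-])o2)cc1` likewise returns a limit, > 200000 nM. Compound 2 therefore stands alone as the one measurable inhibitor, the other two sitting at the limit of > 200000 nM in this assay, at which 2 of the 3 values shown sit.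

Compound 4 `O=C(N/N=C/c1ccc([N+](=O)[O-])o1)c1ccc(-c2ccccc2)cc1` has not yet been measured. It differs from compound 2 in one place: phenyl in place of butylamino on an aromatic carbon. Going by the values given here, the only measured step that resembles this change is an at least 4.2-fold higher number from compound 2 to compound 3 (0.62 log units; beyond the scatter), where the butylamino group also gave way to a carbon-only group. That step was at least modest and pointed toward weaker inhibition, so a step of similar size and direction is expected here in this assay.

Compound 4 is thus expected to give about 200000 nM, within a range of 60000 nM to 1000000 nM, and may well be reported only as a limit. The expected step is a 4.3-fold higher number from compound 2 to compound 4 (0.63 log units; beyond the scatter).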

Compound 4, half-maximal inhibitory concentration: > 200000 nM
Compound 4 was reported as a limit (the forecaster's own chance of this, stated with the estimate: 65%); the middle value lies on the limit itself.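

In this assay, phenyl in place of butylamino gives an at least 4.2-fold higher number from compound 2 to compound 4 (0.62 log units; beyond the scatter), so weaker inhibition now follows a ring as well as the butyl chain at this place, para to a large group. Among compounds 2, 3 and 4, only compound 2, whose group holds a nitrogen, gives a plain number, which suggests that the loss is not tied to one particular carbon-only group. Butyl and phenyl cannot be ranked against each other, because the step between compound 3 and compound 4 cannot be read: the limit of > 200000 nM in this assay, at which 3 of the 4 values shown sit.

From the compounds shown here alone, it remains open whether the nitrogen itself matters or only the whole butylamino group. A butoxy group, with oxygen in place of that nitrogen, or a hexylamino group, with a longer chain on it, would help separate these two readings.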